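Para-hydroxy swap on an inactive triaryl series

The source may report more compounds than this note shows. Statements on the series, on what has been measured and on what is new or still open speak of the compounds shown alone.

Measured in a functional assay on HCT-116 cells (Homo sapiens) for inhibition, read by sulforhodamine B assay, with a stated time of 48 h; on this read-out higher numbers stand for weaker inhibition and lower numbers for stronger inhibition:
- compound 1 `COc1ccc(C(c2ccc(OCCO)cc2)c2cccc3ccccc23)c(OC)c1OC`: > 20000 nM
- compound 2 `COc1ccc(C(c2ccccc2O)c2cccc3ccccc23)c(OC)c1OC`: > 20000 nM

Compound 1 gives > 20000 nM, which is a limit of the assay and not a number. Compound 2 gives > 20000 nM, which is also a limit and not a number. So compound 2 has no numerical position in the series, and the same is true of the only other compound measured: the limit of > 20000 nM in this assay, at which 2 of the 2 values shown sit.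

The change to compound 3 `COc1ccc(C(c2ccc(O)cc2)c2cccc3ccccc23)c(OC)c1OC` is 4-hydroxyphenyl in place of 2-hydroxyphenyl on a saturated chain carbon bound to two aromatic carbons. It places 4-hydroxyphenyl in place of 2-hydroxyphenyl on a saturated chain carbon bound to two aromatic carbons.

Among the measured compounds shown here, the only measured step bearing on this is a step that the two limits leave unreadable from compound 1 to compound 2, and it gives no size to carry over. With no measured size to draw on, any expectation here is weak. At best a modest gain in inhibition is expected, and another limit remains the likeliest result. In this assay the expected step is an at least 1.3-fold lower number from compound 2 to compound 3 (0.12 log units; that floor lies within the scatter). The estimated value for compound 3 is 15000 nM, with an expected range of 4000 nM to 30000 nM.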

Compound 3, half-maximal inhibitory concentration: 16000 nM
Compound 3: middle estimate off by 1.1-fold (0.03 log units), on the low side, within the range that was stated.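

In this assay, among the compounds shown here, compound 3 gives 16000 nM, the first true number, so 4-hydroxyphenyl on the saturated chain carbon bound to two aromatic carbons gives a readable value. The other two compounds stay at a limit of the assay and not at a number: the limit of > 20000 nM in this assay, at which 2 of the 3 values shown sit.

The result supplies an at least 1.2-fold lower number from compound 2 to compound 3 (0.09 log units; that floor lies within the scatter) for the exchange of 2-hydroxyphenyl with the same atoms joined differently, and an at least 1.2-fold lower number from compound 1 to compound 3 (0.09 log units; that floor lies within the scatter) for hydrogen in place of 2-hydroxyethyl on an oxygen on an aromatic ring. From the compounds shown here alone, both are floors rather than measured sizes, each lies within the scatter, and the true size of either step remains unknown. For the compounds shown here, the step between compound 1 and compound 2 cannot be read, so the series offers no measured step between two numbers.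

Going by these compounds, it stays open whether the hydroxyl itself matters for the value of compound 3, which a methoxy group, an amine or a carboxylic acid in its place on the same ring would test. On these data alone, whether any change to the shared core moves inhibition clearly beyond the scatter also remains open.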